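The compounds below may be only part of what the source reports. "The series", "measured", "known", "first", "only" and "open" are said of these compounds alone.

Measured compounds:
Compound 1 `O=S(=O)(NCCCCNCc1ccc(Br)cc1)c1cc(C(F)(F)F)cc(C(F)(F)F)c1`, 2100 nM
Compound 2 `COc1ccc(CNCCCNS(=O)(=O)c2cc(C(F)(F)F)cc(C(F)(F)F)c2)cc1OC`, 2800 nM
Compound 3 `O=S(=O)(NCCCNCC1COc2ccccc2O1)c1cc(C(F)(F)F)cc(C(F)(F)F)c1`, 2600 nM

These numbers come from a functional assay on MIA PaCa-2 cells (Homo sapiens) for inhibition, read by MTT assay, with a stated time of 72 h; on this read-out lower numbers stand for stronger inhibition of growth and higher numbers for weaker inhibition of growth. Compound 3 has the second highest of the three numbers, with compound 2 nearest and compound 1 furthest, yet both gaps are within the scatter, so no ranking among the three can be drawn. Compound 4 `COc1ccccc1CNCCCNS(=O)(=O)c1cc(C(F)(F)F)cc(C(F)(F)F)c1` differs from compound 3 by 2-methoxyphenyl in place of 2,3-dihydro-1,4-benzodioxin-2-yl on a saturated chain carbon bound to an amine nitrogen. For the measured compounds named here, one measured step bears on this, a swap of the ring group at the same chain carbon: a 1.1-fold lower number from compound 2 to compound 3 (0.03 log units; within the scatter). That swap stayed within the scatter. A step no larger than the scatter is therefore expected for compound 4, a 1.0-fold lower number from compound 3 to compound 4 (0.02 log units; within the scatter). Compound 4 is estimated to give 2500 nM, with a likely range from 1200 nM to 5500 nM.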

Compound 4, concentration for 50% growth inhibition: 3100 nM
For compound 4 the middle estimate is 1.2-fold (0.09 log units) below the measured one; the measured number falls inside the stated range.
By their numbers in this assay, from the lowest: compounds 1, 3, 2 and 4 (each within the scatter of the next).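

In this assay, 2-methoxyphenyl at this chain carbon gives a 1.2-fold higher number from compound 3 to compound 4 (0.08 log units; within the scatter) and a 1.1-fold higher number from compound 2 to compound 4 (0.04 log units; within the scatter), so a single-ring group with one oxygen matches both the 2,3-dihydro-1,4-benzodioxin-2-yl and the 3,4-dimethoxyphenyl groups. The larger change of (2-methoxybenzyl)amino in place of ((4-bromobenzyl)amino)methyl also stays small, with a 1.5-fold higher number from compound 1 to compound 4 (0.17 log units; within the scatter). So far, then, these changes leave the number unmoved beyond the scatter. No measurement shown here offers an explanation for this. From the compounds shown here alone, whether a carboxylic acid or a pyridine ring at this chain carbon would give a step beyond the scatter remains open.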